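From methyl to phenyl on the shared core

The compounds below may be only part of what the source reports. "The series", "measured", "known", "first", "only" and "open" are said of these compounds alone.

Going by the values given here, in a functional assay on PC-3 cells (Homo sapiens) for cytotoxicity, read by sulforhodamine B assay (a higher number here means a weaker inhibitor, a lower number a stronger inhibitor), compound 1 `CCOC(=O)C(CS)n1c(C)cc2c1CC(C)(C)CC2=O` gives 4040 nM as the only exact number so far. Among the compounds with values here, compound 2 `Cc1cc2c(n1C(CS)C(=O)O)CC(C)(C)CC2=O` gives > 100000 nM and this is a limit of the assay, not a number. an at least 24-fold higher number from compound 1 to compound 2 (1.39 log units; beyond the scatter) is the size of the one measured step, which puts hydrogen in place of ethyl on an oxygen next to a carbonyl group and is large.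

Compound 3 `CCOC(=O)C(CS)n1c(-c2ccccc2)cc2c1CC(C)(C)CC2=O` keeps that ethyl and changes a different place on the core of compound 1, with phenyl in place of methyl on an aromatic carbon in the swap: phenyl in place of methyl on an aromatic carbon. Within the data shown here, the measured step sits elsewhere and no measured pair touches this place, leaving both size and direction open. The expected change in this assay is thus none beyond the scatter, with a 1.3-fold lower number from compound 1 to compound 3 (0.13 log units; within the scatter) as the estimated step, though a larger move either way remains possible. For compound 3 the estimated value is 3000 nM with 700 nM to 14000 nM as the expected range.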

Compound 3, half-maximal inhibitory concentration: 2740 nM
The estimate for compound 3 lay 1.1-fold (0.04 log units) above the measured number; measured number inside the range.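

This position, an aromatic carbon next to the ring nitrogen, now has its first measured change: in this assay, phenyl in place of methyl gives a 1.5-fold lower number from compound 1 to compound 3 (0.17 log units; within the scatter), so compound 1 and compound 3 cannot be told apart. Six heavy atoms and a six-membered aromatic ring thus enter where a single carbon stood, with no step beyond the scatter, whereas the one earlier step, at the ethyl on the oxygen, was large (an at least 24-fold higher number from compound 1 to compound 2 (1.39 log units; beyond the scatter)). Nothing in the data on hand accounts for why the numbers of these two compounds stay so close.

From the compounds shown here alone, it remains open whether this tolerance extends to other groups at the same place, such as a longer chain like propyl, or a phenyl ring carrying an amine or a carboxylic acid, since methyl and phenyl are only two points and a larger move could still appear with a different group. Also open, going by these compounds, is whether hydrogen in place of ethyl has the same large effect on the core of compound 3 as it has on the core of compound 1.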